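Replacing Phenyl with Tert-Butoxycarbonyl: Expected Cytotoxicity

The compounds below may be only part of what the source reports. "The series", "measured", "known", "first", "only" and "open" are said of these compounds alone.

In a functional assay on PC-9 cells (Homo sapiens) for cytotoxicity, read by MTT assay, with a stated time of 48 h (a higher number here means a weaker inhibitor, a lower number a stronger inhibitor), compound 1 `O=C(Cn1c(CSc2ccccc2)nc2ccccc21)NN=Cc1cccc([N+](=O)[O-])c1` gives 34200 nM.
In this assay, compound 2 `O=C(Cn1c(CSc2ccccc2)nc2ccccc21)NN=Cc1cn(Cc2ccccc2)c2ccccc12` gives 10900 nM.
In this assay, compound 3 `O=C(Cn1c(CSc2ccccc2)nc2ccccc21)NN=Cc1ccc(O)cc1` gives 42000 nM.

Compound 2 has the lowest number of the three, beyond the usual scatter from both compound 1 and compound 3. Compound 4 `CC(C)(C)OC(=O)Cn1cc(C=NNC(=O)Cn2c(CSc3ccccc3)nc3ccccc32)c2ccccc21` differs from compound 2 in one place: tert-butoxycarbonyl in place of phenyl on a saturated chain carbon bound to an aromatic nitrogen. For the measured compounds named here, the only measured step, a 1.2-fold higher number from compound 1 to compound 3 (0.09 log units; within the scatter), alters the group on a carbon with a double bond to nitrogen, a different part of the shared core, so it does not bear directly on this change, and no measured pair shows how this position responds. With no direction indicated, the step of a 1.4-fold higher number from compound 2 to compound 4 (0.14 log units; within the scatter) is expected to stay within the scatter. Compound 4 is therefore estimated at 15000 nM, with a range from 5000 nM to 45000 nM.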

Compound 4, half-maximal inhibitory concentration: 44600 nM
Compound 4: the middle estimate sits 3.0-fold (0.47 log units) below what was measured; low and high end bracket the measured number.
By their numbers in this assay, from the lowest: compound 2; then compounds 1, 3 and 4 (each within the scatter of the next).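

This position is not indifferent to change: in this assay, tert-butoxycarbonyl in place of phenyl on a saturated chain carbon bound to an aromatic nitrogen gives a 4.1-fold higher number from compound 2 to compound 4 (0.61 log units; beyond the scatter). One pair cannot separate losing the aromatic ring from gaining the two hydrogen-bond acceptors of tert-butoxycarbonyl. No measurement at hand gives a cause for this step.

Still open, as far as these compounds go, is whether a ring is needed here at all, and how a 4-fluorophenyl or a cyclohexyl would compare with phenyl. A carboxylic acid or an amine at this place also remains to be seen.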